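Aryloxyalkyl uracils: tolerated concentration in HEL cells

This account rests on a few compounds, and the source may have more. Where it says the series, first, only, none or still open, it means among the compounds named here.

Compound 1 `Cc1ccccc1OCCCCCn1ccc(=O)[nH]c1=O`: in an ADME assay on HEL cells (Homo sapiens) for cytotoxicity, read by microscopy (a lower number here means that less compound is tolerated, a higher number that more compound is tolerated), compound 1 gives > 100000 nM, which is a limit of the assay and not a number.
Compound 2 `CC(C)(C)c1ccc(OCCCCCn2ccc(=O)[nH]c2=O)cc1`: in this assay compound 2 gives 100000 nM.
Compound 3 `O=c1ccn(CCCOc2ccc(Br)cc2)c(=O)[nH]1`: in this assay compound 3 gives > 100000 nM, again a limit of the assay.

Within the data shown here, compound 2 therefore holds the only actual number in this assay; the two remaining values sit at the ceiling, namely (the limit of > 100000 nM in this assay, at which 2 of the 3 values shown sit). Among the measured compounds shown here, no pair of measured compounds differs in a single place, so no measured step is available to lean on.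

Compound 4 `N#Cc1ccc(OCCCCCn2ccc(=O)[nH]c2=O)cc1` differs from compound 2 by cyano in place of tert-butyl on an aromatic carbon.

With compound 2 at 100000 nM, the expected step in this assay is no change at the digits printed from compound 2 to compound 4 (within the scatter), that is, nothing beyond the usual scatter in either direction. Compound 4 is accordingly estimated at 100000 nM, with a range from 50000 nM to 200000 nM. It is quite possible that compound 4 will be reported only as a limit rather than as a number; the measurement will tell.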

Compound 4, minimum cytotoxic concentration: 100000 nM
For compound 4 middle estimate and measured number coincide at the digits printed; the measured number falls inside the stated range.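

Cyano in place of tert-butyl on an aromatic carbon, para to a large group, is the first single-place step in the series, and in this assay it reads no change at the digits printed from compound 2 to compound 4 (within the scatter). At this position, then, the exchange of a group of 4 heavy atoms with no hydrogen-bond acceptor for one of 2 heavy atoms with 1 hydrogen-bond acceptor leaves the tolerated concentration where it was. Compound 4 supplies a second actual number rather than a limit, and the remaining values stay at the ceiling: the limit of > 100000 nM in this assay, at which 2 of the 4 values shown sit.

As far as these compounds go, whether an amine or a carboxylic acid at this position, or a longer chain, would shift the tolerated concentration stays open. With both numbers sitting at the edge of the assay's range, any gain in tolerance would show only as a limit, so the step speaks only to the absence of a drop.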